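This account rests on a few compounds, and the source may have more. Where it says the series, first, only, none or still open, it means among the compounds named here.

In an ADME assay on a cell-free system (plasma, Homo sapiens) for metabolic stability, read by LC-MS (a higher number here means that the compound lasts longer, a lower number that the compound disappears faster), compound 1 `NCc1ccc(C(=O)Nc2ccncc2F)cc1-c1cccc(C(=O)OCC2CCCO2)c1` gives < 0.0834 h as a limit of the assay, not a number. Within the data shown here, compound 2 `CC(C)OCCOC(=O)c1cccc(-c2cc(C(=O)Nc3ccncc3F)ccc2CN)c1` gives 0.1 h and compound 3 `CCCOC(=O)c1cccc(-c2cc(C(=O)Nc3ccncc3F)ccc2CN)c1` gives 0.317 h as the highest number so far. Compound 4 `COC(=O)c1cccc(-c2cc(C(=O)Nc3ccncc3F)ccc2CN)c1` differs from compound 3 by hydrogen in place of ethyl on a saturated chain carbon bound to an oxygen next to a carbonyl group as hydrogen in place of ethyl on a saturated chain carbon bound to an oxygen next to a carbonyl group, or propoxycarbonyl to methoxycarbonyl. Among the measured compounds shown here, two measured steps bear on this, both toward a smaller group: a 3.2-fold higher number from compound 2 to compound 3 (0.50 log units; beyond the scatter) and an at least 3.8-fold higher number from compound 1 to compound 3 (0.57 log units; beyond the scatter) both go upward, so a further small rise in this assay is expected, possibly within the scatter. The expected step is a 1.4-fold higher number from compound 3 to compound 4 (0.15 log units; within the scatter) in this direction. Compound 4 is expected at 0.45 h with an estimated range of 0.2 h to 1 h for the half-life.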

Compound 4, half-life: 1.08 h
Compound 4: middle estimate off by 2.4-fold (0.38 log units), on the low side; the measured number lies above the stated range.
By their numbers in this assay, from the lowest: compound 2; then compound 3; then compound 4. At a limit, below all of these: compound 1.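

In this assay hydrogen in place of ethyl at this carbon gives a 3.4-fold higher number from compound 3 to compound 4 (0.53 log units; beyond the scatter) and so the rise continues from propoxycarbonyl to methoxycarbonyl. The methoxycarbonyl compound also stands clear of the larger groups, with an 11-fold higher number from compound 2 to compound 4 (1.03 log units; beyond the scatter) for the loss of isopropoxymethyl and an at least 12-fold higher number from compound 1 to compound 4 (1.11 log units; beyond the scatter) for the loss of oxolan-2-yl. That last step is only a floor, since compound 1 gives a limit of the assay and not a number: the limit of < 0.0834 h in this assay, at which 1 of the 4 values shown sits.

Open, going by these compounds, is whether the rise holds for an ethyl or isopropyl ester. Also open, on these data alone, is how a carboxylic acid or an amide at this place would compare.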